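Amino for chloro on the fused core: parallel steps

The compounds below may be only part of what the source reports. "The series", "measured", "known", "first", "only" and "open" are said of these compounds alone.

Three members of the series have been tested in a functional assay on OVCAR-8 cells (Homo sapiens) for cytotoxicity, read by sulforhodamine B assay, with a stated time of 48 h; on this read-out lower numbers stand for higher toxicity in this test and higher numbers for lower toxicity in this test. Compound 3 `ClCc1ccc(Cn2cnc3c(Cl)nc(Cl)nc32)cc1` gives 72400 nM in this assay. Compound 2 `ClCc1cccc(Cn2cnc3c(Cl)nc(Cl)nc32)c1` gives 67600 nM in this assay; the gap between compound 2 and compound 3 lies within the scatter, so no order between the two is claimed. Compound 2 and compound 3 are built from the same atoms joined differently, and the difference between the two cores is not broken down here. Compound 1 `Nc1nc(Cl)c2ncn(Cc3ccc(CCl)cc3)c2n1` sits at a limit of this assay, > 100000 nM, and no number is known for it. On these data alone, the change from compound 3 to compound 1 is amino in place of chloro on an aromatic carbon and produces an at least 1.3-fold higher number from compound 3 to compound 1 (0.14 log units; that floor lies within the scatter); its true size is unknown since the value of compound 1 is only a limit (the limit of > 100000 nM in this assay, at which 1 of the 3 values shown sits).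

Compound 4 `Nc1nc(Cl)c2ncn(Cc3cccc(CCl)c3)c2n1` has not yet been measured in this assay. It differs from compound 2 by amino in place of chloro on an aromatic carbon, the same change as from compound 3 to compound 1, at a place described in identical words. Given that compound 2 starts from 67600 nM, close to the starting point of compound 3, the step is expected to carry compound 4 in the same direction, toward a higher number in this assay. The expected step is a 2.2-fold higher number from compound 2 to compound 4 (0.35 log units; beyond the scatter), resting on the measured step from compound 3 to compound 1. Compound 4 is accordingly estimated at 150000 nM, within a range from 70000 nM to 400000 nM, and it may well be reported only as a limit.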

Compound 4, concentration lethal to 50% of the cells: 53700 nM
Compound 4: the middle estimate sits 2.8-fold (0.45 log units) above what was measured, and the stated range ends above it.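

On the core of compound 2, amino in place of chloro on an aromatic carbon gives in this assay a 1.3-fold lower number from compound 2 to compound 4 (0.10 log units; within the scatter), so on this core the change leaves no difference that can be told from the usual scatter of repeated measurements. In this assay compound 1 gives > 100000 nM, which is a limit of the assay and not a number. The two compound pairs therefore neither confirm nor rule out that the change carries from one core to the other with the same direction and size, and they do not show that the choice of core alters its outcome: the same change on two cores in this assay, an at least 1.3-fold higher number (0.14 log units; that floor lies within the scatter) from compound 3 to compound 1 and a 1.3-fold lower number (0.10 log units; within the scatter) from compound 2 to compound 4; the limit leaves it open whether they differ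

Still open, on these data alone, is whether another group in place of the same chloro, such as methoxy or dimethylamino, would give a step beyond the scatter on either core in this assay. Also open, as far as these compounds go, is how hydroxymethyl in place of the chloromethyl group would bear on the numbers, and how the two amino-for-chloro steps would compare if compound 1 had a number rather than a limit.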